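Ethoxy to Trifluoromethoxy: A Small Step Expected

A few compounds are considered here, and "the series" means these few. Any claim that something is new, unique, unknown or untested is made for them only; others in the source may bear on it.

Among the measured compounds shown here, compound 2 `CCOc1ccc2nc(C(=O)Nc3c(F)cc(-c4cccc(F)c4)cc3F)c(C)c(O)c2c1` stands highest of the two numbers so far in a functional assay on A-375 cells (Homo sapiens) for antiproliferative activity, read by MTT assay, with a stated time of 24 h, tested at 0.02 ug/mL (a lower number here means a weaker effect, a higher number a stronger effect of the compound at the concentration tested), where compound 2 gives 0.68%. Compound 1 `Cc1ccc2nc(C(=O)Nc3c(F)cc(-c4cccc(F)c4)cc3F)c(C)c(O)c2c1` gives 0.38% in this assay, and the step of a number 0.3 percentage points higher from compound 1 to compound 2 (within the scatter) lies within the scatter, so the two cannot be ranked against each other. Both numbers sit close to no effect at the concentration tested.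

Compound 3 `Cc1c(C(=O)Nc2c(F)cc(-c3cccc(F)c3)cc2F)nc2ccc(OC(F)(F)F)cc2c1O` differs from compound 2 in one place: trifluoromethyl in place of ethyl on an oxygen on an aromatic ring. For the measured compounds named here, the only measured step that bears on this change, a number 0.3 percentage points higher from compound 1 to compound 2 (within the scatter), concerned a different exchange on the same oxygen-bearing position and stayed within the scatter. Nothing measured here shows a change at this position moving the read-out in this assay beyond the scatter, and both measured compounds lie near the floor of the read-out, leaving little room for a drop. Compound 3 is therefore expected to give 1%, with a range from -5% to 10%. The expected step of a number 0.3 percentage points higher from compound 2 to compound 3 (within the scatter) is estimated to remain within the scatter, in no clear direction.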

Compound 3, a percentage reported as inhibition, at one concentration (the size of the read-out at that concentration, not a potency): -0.35%
For compound 3 the middle estimate is 1.4 percentage points above the measured one; low and high end bracket the measured number.
By their numbers in this assay, from the lowest: compounds 3, 1 and 2 (each within the scatter of the next).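

The exchange of ethoxy for trifluoromethoxy is the first change shown to the group on the oxygen itself, and a number 1 percentage points lower from compound 2 to compound 3 (within the scatter) is what it gives in this assay at this one concentration. Set against the methyl compound, trifluoromethoxy in place of methyl on an aromatic carbon gives a number 0.7 percentage points lower from compound 1 to compound 3 (within the scatter) and so reads the same way, which means that three different groups at this place now yield numbers that cannot be ranked. The earlier pair held no fluorinated group, and this result adds that trifluoromethyl on the oxygen, with its four heavy atoms against the two of ethyl, also leaves the read-out close to no effect.

On these data alone, whether an amine, a carboxylic acid or a longer chain at this place would carry the read-out beyond the scatter stays open. So does whether a higher concentration would separate the three compounds at all, since all of them sit near the floor here. Nothing available explains why these three groups read alike.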